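This account rests on a few compounds, and the source may have more. Where it says the series, first, only, none or still open, it means among the compounds named here.

Compound 3 `COc1ccc(-c2cc(/C=C/C(=O)c3ccccc3)nc3cc(-c4ccccc4)nn23)cc1OC` sits at the second highest of the three numbers available in a functional assay on A549 cells (Homo sapiens) for antiproliferative activity, read by MTT assay, with a stated time of 24 h (a lower number here means a stronger inhibitor, a higher number a weaker inhibitor), where compound 3 gives 10700 nM. Its nearest neighbour is compound 1 `COc1ccc(-c2cc(/C=C/C(=O)c3cc(OC)c(OC)c(OC)c3)nc3cc(-c4ccccc4)nn23)cc1OC`, which in this assay gives 7200 nM; the step of a 1.5-fold higher number from compound 1 to compound 3 (0.17 log units; within the scatter) lies within the scatter. Compound 2 `COc1ccc(-c2cc(C(=O)/C=C/c3ccc(C)cc3)nc3cc(-c4ccccc4)nn23)cc1OC` gives 22200 nM in this assay, and the step of a 2.1-fold lower number from compound 2 to compound 3 (0.32 log units; beyond the scatter) is modest.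

Compound 4 `COc1ccc(-c2cc(/C=C/C(=O)c3ccc(Cl)cc3)nc3cc(-c4ccccc4)nn23)cc1OC` differs from compound 3 by chloro in place of hydrogen on an aromatic carbon. Among the measured compounds shown here, no measured step substitutes on this ring at a single aromatic carbon, so the only bearing comes from compound 1, where a change on the same carbonyl-bearing ring gave the step of a 1.5-fold higher number from compound 1 to compound 3 (0.17 log units; within the scatter), within the scatter, and from compound 2, where a rearranged chalcone gave the modest step of a 2.1-fold lower number from compound 2 to compound 3 (0.32 log units; beyond the scatter). On that evidence only a small step, if any, is expected in this assay, with no confident direction. The author therefore expects compound 4 to give about 8500 nM in this assay, within a range from 3500 nM to 20000 nM. That estimate means a step of a 1.3-fold lower number from compound 3 to compound 4 (0.10 log units; within the scatter), expected to remain within the scatter.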

Compound 4, half-maximal inhibitory concentration: 15400 nM
Estimate against measurement, compound 4: 1.8-fold (0.26 log units) below, within the range that was stated.
By their numbers in this assay, from the lowest: compounds 1, 3, 4 and 2 (each within the scatter of the next, the first and the last beyond it).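

Chloro in place of hydrogen on the six-membered aromatic ring, para to a large group, gives a 1.4-fold higher number from compound 3 to compound 4 (0.16 log units; within the scatter) in this assay and is the first single-carbon substitution seen on this ring, so at this position the new group does not separate compound 4 from compound 3. Against the 3,4,5-trimethoxyphenyl group of compound 1, however, the 4-chlorophenyl group gives a 2.1-fold higher number from compound 1 to compound 4 (0.33 log units; beyond the scatter) and so falls just beyond the scatter, where plain phenyl gave a 1.5-fold higher number from compound 1 to compound 3 (0.17 log units; within the scatter) and stayed within it. The 2-((4-chlorophenyl)carbonyl)ethenyl group also gives a 1.4-fold lower number from compound 2 to compound 4 (0.16 log units; within the scatter) against the (2-(4-methylphenyl)ethenyl)carbonyl group of compound 2, which leaves the two chalcone arrangements apart for compound 3 but not for compound 4.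

One chloro at one carbon leaves open whether a fluoro, a methoxy, an amine or a carboxylic acid at the same carbon would move the number beyond the scatter, and whether chloro would read the same on the other carbons of this ring. Nothing available here accounts for any of these steps.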